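The source may hold more compounds than are shown below. What is called first, only, known or untested is meant among the compounds shown, and "the series" means these compounds.

Measured compounds:
compound 1 `COc1ccc(/C=C/[C@H]2CC=CC(=O)O2)cc1` — > 100000 nM
compound 2 `O=C1CCC[C@H]([C@@H]2C[C@H]2c2ccccc2)O1` — > 100000 nM

In a functional assay on MCF7 cells (Homo sapiens) for antiproliferative activity, read by luminescence and CellTiter-Glo, with a stated time of 48 h (a higher number here means a weaker inhibitor, a lower number a stronger inhibitor), compound 1 gives > 100000 nM, which is a limit of the assay rather than a measured number. Compound 2, whose structure is `O=C1CCC[C@H]([C@@H]2C[C@H]2c2ccccc2)O1`, is also recorded in this assay only as a limit, > 100000 nM. So compound 1 stands at the limit, and the only other value shown sits there as well: the limit of > 100000 nM in this assay, at which 2 of the 2 values shown sit. Among the compounds with values here, nothing measured so far separates the two compounds, and no comparison between them can be drawn beyond saying that both fall at the limit.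

Compound 3, `O=C1C=CC[C@H](/C=C/c2ccc(F)cc2)O1`, has not yet been measured in this assay. It differs from compound 1 in one place: fluoro in place of methoxy on an aromatic carbon.

Within the data shown here, with both measured compounds at the limit, no step between measured values is available to guide the direction of this change. Compound 3 is expected to remain close to where compound 1 stands in this assay, with a step from compound 1 of a step that the limit leaves unreadable from compound 1 to compound 3, likely none beyond the scatter. The estimate for compound 3 in this assay is 150000 nM, in the range 60000 nM to 400000 nM, most probably again reported only as a limit.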

Compound 3, half-maximal inhibitory concentration: 76200 nM
Beside the measured number, compound 3's estimate is 2.0-fold (0.29 log units) above it; the measured number falls inside the stated range.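

Of the three compounds shown, compound 3 is the only one that gives a number rather than a limit in this assay, which shows that the shared core with fluoro on this aromatic carbon can be read within the range of the assay. Set against methoxy at the same place, the change gives an at least 1.3-fold lower number from compound 1 to compound 3 (0.11 log units; that floor lies within the scatter). This floor does not establish a real difference between the two groups, and the true size of the step stays unknown because compound 1 is recorded only as a limit: the limit of > 100000 nM in this assay, at which 2 of the 3 values shown sit.

The compounds shown leave open how other groups on this aromatic carbon, such as chloro, trifluoromethyl, an amine or a carboxylic acid, would read in this assay, and whether any of them would give a step clearly beyond the scatter. From the compounds shown here alone, compound 2 differs from compound 3 in more than one place, so it says nothing about this change, and what the remainder of the core contributes also stays open.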